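The source may hold more compounds than are shown below. What is called first, only, known or untested is meant among the compounds shown, and "the series" means these compounds.

Measured so far:
compound 1, `O=C(Nc1ccc(Cl)cc1)c1cc(=O)[nH]c2cc(Br)ccc12`: > 20000 nM
compound 2, `CC(=O)c1ccc(-c2ccc3c(C(=O)Nc4cccc(F)c4)cc(=O)[nH]c3c2)cc1`: > 20000 nM

Both entries in a functional assay on KYSE-410 cells (Homo sapiens) for antiproliferative activity, read by MTT assay, with a stated time of 72 h (on this read-out lower numbers stand for stronger inhibition and higher numbers for weaker inhibition), are limits of the assay rather than numbers. Compound 1 reaches only the limit > 20000 nM in this assay. Compound 2 likewise reaches only the limit > 20000 nM in this assay, so compound 2 stands with compound 1 at the limit of > 20000 nM in this assay, at which 2 of the 2 values shown sit, and neither value can be ranked against the other.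

Compound 3, `O=C(Nc1cccc(F)c1)c1cc(=O)[nH]c2cc(-c3cccnc3F)ccc12`, is not yet measured. It differs from compound 2 in one place: 2-fluoropyridin-3-yl in place of 4-acetylphenyl on an aromatic carbon. Within the data shown here, the pair of compound 1 and compound 2 gives no measured step, and the two limits carry no information on how the group at this position moves the read-out.

With nothing in the measured set that departs from the limit, the expected step from compound 2 to compound 3 in this assay is none beyond the scatter, a step that the limit leaves unreadable from compound 2 to compound 3. Compound 3 is therefore estimated at 25000 nM in this assay, with a range from 4000 nM to 100000 nM, and most likely it will again be reported only as a limit.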

Compound 3, half-maximal inhibitory concentration: 11600 nM
Compound 3: the middle estimate sits 2.2-fold (0.33 log units) above what was measured, and the stated range covers the measured number.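

In this assay compound 3 gives 11600 nM, the first entry in the series that is a number rather than a limit, so at least one group on this aromatic carbon brings the read-out within the measurable range. From the compounds shown here alone, replacing 4-acetylphenyl with 2-fluoropyridin-3-yl gives an at least 1.7-fold lower number from compound 2 to compound 3 (0.23 log units; that floor lies within the scatter); this is only a floor, so the true size of the step remains unknown and a change beyond the scatter is not established. Compound 3 therefore separates from the rest of the set only as far as that floor allows, and the other entries remain at one shared limit: the limit of > 20000 nM in this assay, at which 2 of the 3 values shown sit.

Going by these compounds, it remains open which feature of the entering group goes with the measured number, the ring nitrogen, the fluorine or the smaller group as a whole; a plain pyridin-3-yl and a 2-fluorophenyl at this position would separate these. Also open, on these data alone, is whether an amine or a carboxylic acid on the same aromatic carbon would give a lower number in this assay or return the read-out to the limit.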